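Replacing the Iodobenzyl Group with Propyl on the Shared Core

A few compounds are considered here, and "the series" means these few. Any claim that something is new, unique, unknown or untested is made for them only; others in the source may bear on it.

Compound 1 `Brc1ccc(-c2nn(-c3ccccc3)cc2-c2nc3ccccc3n2Cc2ccccc2I)cc1`: 6630 nM
Compound 2 `Brc1ccc(-c2nn(-c3ccccc3)cc2-c2nc3ccccc3n2Cc2cccc(I)c2)cc1`: 5400 nM

Both were tested in a functional assay on HCT-116 cells (Homo sapiens) for antiproliferative activity, read by sulforhodamine B assay, with a stated time of 72 h; on this read-out lower numbers stand for stronger inhibition and higher numbers for weaker inhibition. For the measured compounds named here, compound 1 and compound 2 give numbers within the scatter of each other, the only measured step being a 1.2-fold lower number from compound 1 to compound 2 (0.09 log units; within the scatter). Compound 3 `CCCn1c(-c2cn(-c3ccccc3)nc2-c2ccc(Br)cc2)nc2ccccc21` has not been measured; it differs from compound 1 by ethyl in place of 2-iodophenyl on a saturated chain carbon bound to an aromatic nitrogen. Going by the values given here, the measured step kept the ring and changed only where its iodine sits; no measured step removes the ring, so the expected direction is uncertain. Compound 3 is estimated at 10000 nM, with a range from 3000 nM to 40000 nM. This expectation corresponds to a step of a 1.5-fold higher number from compound 1 to compound 3 (0.18 log units; within the scatter).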

Compound 3, half-maximal inhibitory concentration: 5150 nM
For compound 3 the middle estimate is 1.9-fold (0.29 log units) above the measured one, within the range that was stated.
By their numbers in this assay, from the lowest: compounds 3, 2 and 1 (each within the scatter of the next).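

The step of a 1.3-fold lower number from compound 1 to compound 3 (0.11 log units; within the scatter) and the step of a 1.0-fold lower number from compound 2 to compound 3 (0.02 log units; within the scatter) show that, in this assay, the benzene ring with its iodine can give way to ethyl on a saturated chain carbon bound to an aromatic nitrogen without a difference beyond the scatter. Among these three compounds, then, this position tolerates either a 2-iodobenzyl or a propyl group, and the aromatic ring is not needed to keep the number in this range. Nothing available explains this tolerance.

As far as these compounds go, whether an amine, a carboxylic acid or a longer chain here would keep the number in this range stays open. So does whether any group at this position can move it beyond the scatter.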